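The source may hold more compounds than are shown below. What is called first, only, known or untested is meant among the compounds shown, and "the series" means these compounds.

Working notes on a small set built around the core of compound 1 `COc1ccc(-c2cc(/C=C/C(=O)c3ccc(N)cc3)[nH]n2)cc1`. For the measured compounds named here, in a functional assay on ACHN cells (Homo sapiens) for inhibition, read by sulforhodamine B assay, with a stated time of 48 h (a lower number here means that less compound is tolerated, a higher number that more compound is tolerated), compound 1 gives 49200 nM, the only plain number recorded so far. Compound 2 `COc1cc(-c2cc(/C=C/C(=O)c3ccc(Cl)c(Cl)c3)[nH]n2)cc(OC)c1OC`, which carries further methoxy groups on one ring and chlorines in place of the amine on the other, is reported in this assay only as a limit, > 100000 nM. the limit of > 100000 nM in this assay, at which 1 of the 2 values shown sits, marks the point at which one of the two recorded values sits. Going by the values given here, compound 1 and compound 2 differ in more than one place, so their two values show only that compound 1 reaches a measurable concentration while compound 2 does not within the tested range. Compound 3 `COc1ccc(-c2cc(/C=C/C(=O)c3ccc(N)cc3)[nH]n2)cc1OC` is not yet measured. It differs from compound 1 by methoxy in place of hydrogen on an aromatic carbon. Among the compounds with values here, no measured pair isolates this change, so nothing anchors its size. The step from compound 1 to compound 3 is expected to be a 1.2-fold higher number from compound 1 to compound 3 (0.09 log units; within the scatter), a shift judged to lie within or only slightly beyond the scatter, toward more compound tolerated. For compound 3 the estimated value in this assay is 60000 nM, with a range from 25000 nM to 150000 nM.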

Compound 3, concentration lethal to 50% of the cells: 6480 nM
Beside the measured number, compound 3's estimate is 9.3-fold (0.97 log units) above it; measured number below the stated range.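

In this assay, methoxy in place of hydrogen on an aromatic carbon, ortho to a methoxy group and meta to a large group, gives a 7.6-fold lower number from compound 1 to compound 3 (0.88 log units; beyond the scatter). For the compounds shown here, this is the first step in the set that isolates a single change, and it shows that this aromatic carbon is not a silent position: the added methoxy moves the series toward less compound tolerated, by an amount that clears the scatter. Nothing recorded for these compounds accounts for the direction or the size of this step.

A single step cannot show whether the shift belongs to methoxy itself or would follow from any group entering at this carbon, and an ethoxy group, a hydroxy group or a chlorine at the same place would separate those two readings. As far as these compounds go, whether the step keeps its size when another group, such as an acetamide or a nitro group, stands in place of the amine on the shared core also remains open, as does whether it carries beyond this one cell line.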